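Replacing a Group on a Sulfonyl Sulfur

A few compounds are considered here, and "the series" means these few. Any claim that something is new, unique, unknown or untested is made for them only; others in the source may bear on it.

In an ADME assay on microsomes from liver (Homo sapiens) for pharmacokinetics, read by LC-MS, with a stated time of 60 min, tested at 1 uM (on this read-out lower numbers stand for slow clearance and higher numbers for fast clearance), compound 1 `O=C(NCc1cnccn1)Nc1ccc(S(=O)(=O)c2ccccc2)cc1` reads 5 mL/min/kg and compound 2 `Nc1ncc(CNC(=O)Nc2ccc(S(=O)(=O)c3ccccc3)cc2)cn1` reads 3 mL/min/kg while compound 3 `O=C(NCc1cccnc1)Nc1ccc(S(=O)(=O)N2CCC3(CCNC3)CC2)cc1` reads 4 mL/min/kg and so stands within the scatter of both. The change to compound 4 `O=C(NCc1cccnc1)Nc1ccc(S(=O)(=O)N[C@H]2CC[C@H](O)CC2)cc1` is a group of 8 heavy atoms (6 carbon, 1 nitrogen, 1 oxygen; one six-membered non-aromatic ring of carbon only) in place of a group of 10 heavy atoms (8 carbon, 2 nitrogen; one five-membered non-aromatic ring with 1 hetero atom, one six-membered non-aromatic ring with 1 hetero atom), on a sulfonyl sulfur and the group that enters is (4-hydroxycyclohexyl)amino. Among the measured compounds shown here, the only measured step is a 1.7-fold lower number from compound 1 to compound 2 (0.22 log units; within the scatter) and it lies within the scatter, but it concerns a different group, so it offers no direct precedent for this exchange. In this assay the expected result is a 1.3-fold higher number from compound 3 to compound 4 (0.10 log units; within the scatter) and no step beyond the scatter. For compound 4 the estimated value is 5 mL/min/kg with an expected range from 2.5 mL/min/kg to 10 mL/min/kg in this read-out.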

Compound 4, clearance: 2 mL/min/kg
The estimate for compound 4 lay 2.5-fold (0.40 log units) above the measured number; measured number below the stated range.
By their numbers in this assay, from the lowest: compounds 4, 2, 3 and 1 (each within the scatter of the next, the first and the last beyond it).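

In this assay, putting (4-hydroxycyclohexyl)amino on the sulfonyl sulfur in place of the two-ring group gives a 2.0-fold lower number from compound 3 to compound 4 (0.30 log units; within the scatter). This is the first exchange shown at this position, and it indicates that clearance stays within the scatter across two quite different groups there. No measurement bears on why this is so. The compounds shown leave open whether a simple open-chain group such as dimethylamino would read alike on the sulfonyl sulfur. They also leave open whether a carboxylic acid in place of the hydroxy group on the cyclohexyl ring would do so.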